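Swapping an Aminobenzyl for a Dichlorobenzyl Group

The compounds below may be only part of what the source reports. "The series", "measured", "known", "first", "only" and "open" are said of these compounds alone.

Of the compounds shown here, three have so far been tested in an assay for inhibition of MAP kinase-interacting serine/threonine-protein kinase 2 (Homo sapiens), read by luminescence and ADP-Glo, with a stated time of 2 h; on this read-out higher numbers stand for weaker inhibition and lower numbers for stronger inhibition. Compound 1 `O=c1ccc(-c2n[nH]c3ncc(Br)cc23)cn1Cc1ccccc1` gives 12 nM. Compound 2 `Nc1cccc(Cn2cc(-c3ccc4cn[nH]c4c3)ccc2=O)c1` gives 84 nM, the highest of the three numbers, which on this read-out means the weakest inhibition. Compound 3 `Nc1n[nH]c2cc(-c3ccc(=O)n(Cc4cccc(F)c4)c3)ccc12` gives 5 nM. The gaps from compound 2 to compound 1 and to compound 3 both lie beyond the usual scatter, so compound 2 is the weakest inhibitor among the measured three. No two of these compounds differ in only one place, so no single change can be credited for any gap.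

Compound 4 `O=c1ccc(-c2ccc3cn[nH]c3c2)cn1Cc1ccc(Cl)c(Cl)c1` has not yet been measured. It differs from compound 2 in one place: 3,4-dichlorophenyl in place of 3-aminophenyl on a saturated chain carbon bound to an aromatic nitrogen. Compounds 1 and 3, neither of which carries an aminophenyl group, both give lower numbers than compound 2, but each also differs from it elsewhere, so they offer only a hint.

The expected step of a 2.8-fold lower number from compound 2 to compound 4 (0.45 log units; beyond the scatter) is a modest move towards stronger inhibition, although an outcome within the scatter would not be surprising. Compound 4 is therefore estimated at 30 nM, with a range from 10 nM to 100 nM.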

Compound 4, half-maximal inhibitory concentration: 97 nM
Compound 4: the middle estimate sits 3.2-fold (0.51 log units) below what was measured; the range from low to high includes it.
By their numbers in this assay, from the lowest: compound 3; then compound 1; then compounds 2 and 4 (each within the scatter of the next).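

At this position, on a saturated chain carbon bound to an aromatic nitrogen, putting 3,4-dichlorophenyl in place of 3-aminophenyl gives a 1.2-fold higher number from compound 2 to compound 4 (0.06 log units; within the scatter) in this assay, so this pair shows no measurable difference. The two groups are far from alike on paper: 3-aminophenyl brings a hydrogen-bond donor and a hydrogen-bond acceptor, while 3,4-dichlorophenyl brings neither and carries two chlorine atoms, yet on this core the exchange leaves the read-out unchanged within the scatter, so the 3-aminophenyl group is not shown to be what sets the level of inhibition here. Nothing available explains why two such different groups give matching numbers.

Going by these compounds, it remains open whether a quite different group at this place, such as a carboxylic acid on the ring or a longer chain carrying the ring, would move the number beyond the scatter. On these data alone, it is also open whether the same exchange would turn out equally flat on the cores of compound 1 and compound 3, which differ from compound 2 in more than one place.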